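Moving the Pyrazole Link from Compound 2 to Compound 3

The source may hold more compounds than are shown below. What is called first, only, known or untested is meant among the compounds shown, and "the series" means these compounds.

In a functional assay on A2780 cells (Homo sapiens) for inhibition (on this read-out higher numbers stand for weaker inhibition and lower numbers for stronger inhibition), compound 1 `CCNC(=O)c1noc(-c2cc(C(C)C)c(O)cc2O)c1-c1cc(CO)no1` gives 5 nM, while compound 2 `CCNC(=O)c1noc(-c2cc(C(C)C)c(O)cc2O)c1-c1ccn(CC)n1` gives 13 nM, the higher of the two numbers and so the weaker inhibition. Compound 3 `CCNC(=O)c1noc(-c2cc(C(C)C)c(O)cc2O)c1-c1cnn(CC)c1` is still unmeasured. It holds the same atoms as compound 2, joined differently: 1-ethyl-1H-pyrazol-4-yl in place of 1-ethyl-1H-pyrazol-3-yl on an aromatic carbon. The change lies on an aromatic carbon of a five-membered aromatic ring with 1 nitrogen and 1 oxygen. Going by the values given here, only one measured step bears on it, a 2.6-fold higher number from compound 1 to compound 2 (0.41 log units; beyond the scatter). That modest step lies beyond the scatter, but it exchanged two different groups, whereas here only the attachment of the pyrazole moves. Among the compounds with values here, no measurement yet shows what such a move does, so no firm direction can be argued. The expected step in this assay, a 1.2-fold higher number from compound 2 to compound 3 (0.06 log units; within the scatter), stays within the scatter. Compound 3 is estimated at 15 nM, with an expected range of 5 nM to 45 nM.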

Compound 3, half-maximal inhibitory concentration: 30 nM
Compound 3: middle estimate off by 2.0-fold (0.30 log units), on the low side; measured number inside the range.
By their numbers in this assay, from the lowest: compound 1; then compound 2; then compound 3.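

In this assay, the joining of the pyrazole proves to matter by itself: with the same atoms on the same aromatic carbon, 1-ethyl-1H-pyrazol-4-yl in place of 1-ethyl-1H-pyrazol-3-yl gives a step beyond the scatter (a 2.3-fold higher number from compound 2 to compound 3 (0.36 log units; beyond the scatter)). The earlier step exchanged two different groups, so it could not separate what a group contains from how it is attached. The exchange of 3-(hydroxymethyl)-1,2-oxazol-5-yl for the new pyrazole gives a larger step (a 6.0-fold higher number from compound 1 to compound 3 (0.78 log units; beyond the scatter)), but no measurement here explains why either change weakens inhibition.

Still open, on these data alone, is how the 1-ethyl-1H-pyrazol-3-yl and 1-ethyl-1H-pyrazol-4-yl groups would compare with a methyl or a longer propyl chain in place of the ethyl. As far as these compounds go, it is also open whether a hydroxymethyl group on either pyrazole would bring the number closer to that of compound 1 (5 nM).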